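A few compounds are considered here, and "the series" means these few. Any claim that something is new, unique, unknown or untested is made for them only; others in the source may bear on it.

Of the compounds shown here, two of one shared core have been tested in a functional assay on the whole organism (strain Wistar albino) for inhibition, with Rattus norvegicus as the target, read by paw edema, with a stated time of 1 h, at a dose of 25 mg/kg by the oral route; a lower number here means less inhibition, a higher number more inhibition at the dose given (going by the name of the read-out). Compound 1, `NS(=O)(=O)c1ccc(-n2nc(Nc3ccc([N+](=O)[O-])cc3)c3c(=O)n(-c4ccccc4)c(Nc4ccccc4)nc32)cc1`, gives 67% in this assay. Compound 2, `O=c1c2c(Nc3ccc(Cl)cc3)nn(-c3ccc([N+](=O)[O-])cc3)c2nc(Nc2ccccc2)n1-c1ccccc1`, gives 39.6%, the lower of the two by a gap beyond the usual scatter. Compound 3, `NS(=O)(=O)c1ccc(-n2nc(Nc3ccc(Cl)cc3)c3c(=O)n(-c4ccccc4)c(Nc4ccccc4)nc32)cc1`, has not yet been measured; it arises from compound 2 through (sulfamoyl in place of nitro on an aromatic carbon). Among the compounds with values here, no step between measured compounds isolates this change, so the expectation rests on the two values shown. Compound 1, which carries the same sulfamoylphenyl group and gives 67%, suggests an upward step, and the estimated step from compound 2 to compound 3 is a number 15.4 percentage points higher from compound 2 to compound 3 (beyond the scatter). Compound 3 is thus expected to give about 55%, within a range of 38% to 72%.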

Compound 3, a percentage reported as inhibition, in the whole organism at one dose (the size of the read-out at that dose, not a potency): 69.8%
Compound 3: middle estimate off by 14.8 percentage points, on the low side; measured number inside the range.
By their numbers in this assay, from the lowest: compound 2; then compounds 1 and 3 (each within the scatter of the next).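

In this assay the exchange of 4-nitrophenyl for 4-sulfamoylphenyl now stands as a direct step, a number 30.2 percentage points higher from compound 2 to compound 3 (beyond the scatter) with the rest of the molecule unchanged. With the sulfamoyl group in place, chloro in place of nitro on the other aromatic carbon gives a number 2.8 percentage points higher from compound 1 to compound 3 (within the scatter) so this pair cannot be told apart here. On these data alone, whether a carboxylic acid or an amine on that aromatic carbon would give a similar step remains open. No measurement shown gives a cause for the step.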